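This account rests on a few compounds, and the source may have more. Where it says the series, first, only, none or still open, it means among the compounds named here.

Measured in an ADME assay on HEK-293T cells (Homo sapiens) for cytotoxicity, read by luminescence, with a stated time of 24 h (a lower number here means that less compound is tolerated, a higher number that more compound is tolerated), read as the half-maximal cytotoxic concentration:

- compound 1 `COc1ccc(Cn2c(C(=O)NCc3ccccc3)cc3sccc32)cc1`: > 100000 nM (a limit)
- compound 2 `CCN(CC)C(=O)c1cc2sccc2n1Cc1ccc(OC)cc1`: > 100000 nM (a limit)
- compound 3 `CCOC(=O)C1CCN(C(=O)c2cc3sccc3n2Cc2ccc(OC)cc2)CC1`: 39000 nM

Compound 1 stands at the limit of > 100000 nM in this assay, at which 2 of the 3 values shown sit. Its entry is a limit and not a number, so any step starting from compound 1 has an open end.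

Next in the series is compound 4 `COc1ccc(Cn2c(C(=O)N3CCC(C(N)=O)CC3)cc3sccc32)cc1`, not yet measured. The change is 4-carbamoylpiperidin-1-yl in place of benzylamino on a carbonyl carbon.

Going by the values given here, the one measured step at this place is a step that the two limits leave unreadable from compound 1 to compound 2. Among the compounds with values here, it gives no size, and it shows only that this swap leaves compound 2 at a limit as well. Within the data shown here, compound 3 also has a six-membered non-aromatic ring on that carbonyl carbon, and compound 3 gives 39000 nM, the only actual number in the set.

In this assay, no step beyond the scatter is expected, and any movement is expected toward less compound tolerated, on the evidence of compound 3 at 39000 nM. The expected change is an at least 1.2-fold lower number from compound 1 to compound 4 (0.09 log units; that floor lies within the scatter). For compound 4 the estimate is 80000 nM, with an expected range of 30000 nM to 200000 nM.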

Compound 4, half-maximal cytotoxic concentration: > 100000 nM
Compound 4: no number, only a limit; the forecaster's own chance of this, stated with the estimate: 55%; middle value at least 1.2-fold (0.09 log units) away from the limit.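

In this assay compound 4 gives a limit and not a number: the limit of > 100000 nM in this assay, at which 3 of the 4 values shown sit.

The new information comes from compound 3, which keeps the six-membered non-aromatic ring on the carbonyl carbon: amino in place of ethoxy on a carbonyl carbon gives an at least 2.5-fold higher number from compound 3 to compound 4 (0.40 log units; beyond the scatter), and this size is a floor. The ring alone therefore does not bring the number down, and within this pair the reading turns on the ethoxy or amino group. The steps from compound 1 and compound 2 to compound 4 cannot be read, so benzylamino, diethylamino and 4-carbamoylpiperidin-1-yl cannot be ranked against each other.

As far as these compounds go, the finding rests on a single pair, with compound 3 the only entry that carries an actual number, so it is open whether the lower number goes with ethoxy specifically or with other groups on that carbonyl carbon. A hydroxy group, which would give the carboxylic acid, or a methoxy group or a longer alkoxy chain in the same place would separate these readings.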